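This account rests on a few compounds, and the source may have more. Where it says the series, first, only, none or still open, it means among the compounds named here.

Of the compounds shown here, two have so far been measured in an ADME assay on Huh-7 cells (Homo sapiens) for cytotoxicity; a lower number here means that less compound is tolerated, a higher number that more compound is tolerated. Compound 1 `CN1CCN(CCNCc2cn(-c3ccc(F)cc3F)nc2-c2ccc(Cl)cc2)CC1` gives 19000 nM in this assay, and compound 2 `Cc1ccccc1-c1nn(-c2ccc(Cl)cc2)cc1CNCCN1CCN(C)CC1` gives 17000 nM, the two numbers lying within the usual scatter of each other. Compound 3 `Cc1ccccc1-c1nn(-c2ccc(F)cc2)cc1CNCCN1CCN(C)CC1` has not yet been measured. It differs from compound 2 by fluoro in place of chloro on an aromatic carbon. Among the measured compounds shown here, no pair of measured compounds carries this change, so the step from compound 2 to compound 3 is expected to stay within the scatter, perhaps with slightly more compound tolerated: a 1.2-fold higher number from compound 2 to compound 3 (0.07 log units; within the scatter). Compound 3 is therefore estimated at 20000 nM, with a range from 10000 nM to 40000 nM.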

Compound 3, half-maximal cytotoxic concentration: > 20000 nM
Compound 3 was reported as a limit; the forecaster's own chance of this, stated with the estimate: 10%; the middle value sits exactly at the limit.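

In this assay compound 3 stands at a limit of the assay and not at a number: the limit of > 20000 nM in this assay, at which 1 of the 3 values shown sits. Going from 4-chlorophenyl to 4-fluorophenyl gives an at least 1.1-fold higher number from compound 2 to compound 3 (0.07 log units; that floor lies within the scatter), so this step can be read only as a floor and its true size stays unknown. Among the compounds shown here, it is the first look at this position, and with fluoro in place of chloro, no lower number appears.

The compounds shown leave open how far compound 3 lies past the limit. They also leave open what a methoxy group or an amine would give at this position.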